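Aryl methyl on the sulfonamide ring: compound 3 to compound 4

The source may report more compounds than this note shows. Statements on the series, on what has been measured and on what is new or still open speak of the compounds shown alone.

Compound 3 `O=C(O)c1ccc(NC(=O)[C@@H]2CCCN2S(=O)(=O)c2ccccc2)cc1` gives 31.2% in a functional assay on the whole organism for inhibition, with Rattus norvegicus as the target, read by paw edema, with stated times of 1 h and 3 h, at a dose of 100 mg/kg by the oral route (a lower number here means less inhibition, a higher number more inhibition at the dose given (going by the name of the read-out)), the lowest of the three numbers in hand. Compound 2 `Cc1ccccc1S(=O)(=O)N1CCC[C@H]1C(=O)Nc1ccc(C(=O)O)cc1` gives 40.1%, and compound 1 `Cc1ccc(S(=O)(=O)N2CC(O)C[C@H]2C(=O)Nc2ccc(C(=O)O)cc2)cc1` gives 84%; the gap from compound 3 to compound 2 is within the scatter, the gap to compound 1 is beyond it, but compound 1 is not a single-change neighbour of compound 3 or of compound 4.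

Compound 4 `Cc1ccc(S(=O)(=O)N2CCC[C@H]2C(=O)Nc2ccc(C(=O)O)cc2)cc1` differs from compound 3 by methyl in place of hydrogen on an aromatic carbon.

For the measured compounds named here, the one measured step that bears on this is a number 8.9 percentage points lower from compound 2 to compound 3 (within the scatter), methyl removed from an aromatic carbon of the same ring. Compound 4 is the reverse kind of change, methyl in place of hydrogen on an aromatic carbon, though compound 2 and compound 4 are not themselves a listed pair, so that step is a guide rather than a copy. Read in reverse, it points to a small rise, within the scatter.

The expectation for compound 4 is therefore a step of a number 8.8 percentage points higher from compound 3 to compound 4 (within the scatter), a modest rise and not a change that would clear the scatter on its own. Compound 4 is estimated at 40%, with a range from 22% to 62%.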

Compound 4, a percentage reported as inhibition, in the whole organism at one dose (the size of the read-out at that dose, not a potency): 35.3%
Compound 4: middle estimate off by 4.7 percentage points, on the high side; the range from low to high includes it.
By their numbers in this assay, from the lowest: compounds 3, 4 and 2 (each within the scatter of the next); then compound 1.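

In this assay the change from phenyl to 4-methylphenyl gives a number 4.1 percentage points higher from compound 3 to compound 4 (within the scatter) and shifting the methyl gives a number 4.8 percentage points lower from compound 2 to compound 4 (within the scatter) so neither adding this methyl nor its placement separates compound 2, compound 3 and compound 4 at this dose. Compound 4 also gives compound 1 its first single-change neighbour, and the step of a number 48.7 percentage points lower from compound 1 to compound 4 (beyond the scatter) places the one large difference seen so far at the saturated ring carbon carrying hydroxy, with the aromatic methyl steps all inside the scatter. No measurement in hand accounts for any of these steps.

As far as these compounds go, whether an amine or a methoxy group on that saturated ring carbon would match the read-out of compound 1 stays open, as does whether hydroxy there would give a step of similar size on the unsubstituted phenyl of compound 3. Also open, from the compounds shown here alone, is whether a longer chain such as ethyl, or a chlorine atom, in place of the methyl of compound 4 would move the read-out beyond the scatter.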